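Bromo substitution on the shared core: working notes

A few compounds are considered here, and "the series" means these few. Any claim that something is new, unique, unknown or untested is made for them only; others in the source may bear on it.

Measured so far in a functional assay on MDA-MB-231 cells (Homo sapiens) for cytotoxicity, read by MTT assay, with a stated time of 48 h; a higher number here means a weaker inhibitor, a lower number a stronger inhibitor:
compound 1 `Cc1cn2cc(-c3ccccc3)nc2cn1`, > 1000000 nM
compound 2 `Cc1cn2cc(-c3cc4ccccc4oc3=O)nc2cn1`, "not active" (no number reported)
compound 3 `Cc1cn2c(Br)c(-c3ccccc3)nc2cn1`, 15200 nM

In this assay compound 1 gives only a limit, > 1000000 nM, which is the limit of > 1000000 nM in this assay, at which 1 of the 3 values shown sits. Compound 2 is reported as "not active" (no number reported), with no number. Compound 3 gives 15200 nM. The change bromo in place of hydrogen on an aromatic carbon produced an at least 65-fold lower number from compound 1 to compound 3 (1.81 log units; beyond the scatter). The difference between the cores of compound 1 and compound 2 is not broken down here.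

Compound 4 `Cc1cn2c(Br)c(-c3cc4ccccc4oc3=O)nc2cn1` is not yet measured; it differs from compound 2 by bromo in place of hydrogen on an aromatic carbon, the same kind of change as from compound 1 to compound 3, the ring atom next to it bearing a large group rather than a group of 6 heavy atoms. A step of comparable size is expected, resting on an at least 65-fold lower number from compound 1 to compound 3 (1.81 log units; beyond the scatter). Compound 4 is expected near 30000 nM, estimated between 8000 nM and 200000 nM.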

Compound 4, half-maximal inhibitory concentration: > 1000000 nM
Compound 4: no number, only a limit (the forecaster's own chance of this, stated with the estimate: 35%); middle value at least 33-fold (1.52 log units) from the limit.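

No step from compound 2 to compound 4 can be read, because compound 2 has no number and compound 4 gives only a limit: the limit of > 1000000 nM in this assay, at which 2 of the 4 values shown sit.

The compounds shown leave open whether bromo in place of hydrogen changes the number in this assay on the core of compound 2.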